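This account rests on a few compounds, and the source may have more. Where it says the series, first, only, none or still open, it means among the compounds named here.

Working notes on the series. In an ADME assay on microsomes from liver (Canis lupus familiaris) for metabolic stability (on this read-out lower numbers stand for a shorter-lived compound and higher numbers for a longer-lived compound), compound 1 (`FC(F)(F)c1ccc(NCCNc2ncc(-c3ncc[nH]3)c(-c3ccc(Cl)cc3Cl)n2)nc1`) gives > 0.5 h as a limit of the assay, not a number. Compound 2 (`Nc1nc(NCCNc2ncc(-c3ncc[nH]3)c(-c3cc(F)c(F)cc3F)n2)ccc1[N+](=O)[O-]`) gives > 0.5 h in this assay as well, so its standing is known only as a limit. Among the compounds with values here, the same limit holds all the data so far (the limit of > 0.5 h in this assay, at which 2 of the 2 values shown sit), and no step between measured compounds is available to scale from.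

The next compound is compound 3 (`Nc1nc(NCCNc2ncc(-c3ncc[nH]3)c(-c3ccc(Br)cc3F)n2)ccc1[N+](=O)[O-]`). It carries 4-bromo-2-fluorophenyl in place of the 2,4,5-trifluorophenyl of compound 2 on an aromatic carbon (4-bromo-2-fluorophenyl in place of 2,4,5-trifluorophenyl on an aromatic carbon), at the place next to the ring nitrogen and ortho to a 1H-imidazol-2-yl group.

With compound 2 at > 0.5 h as a limit, no change beyond the usual scatter is expected in this assay in either direction. The expected size of the change is small (a step that the limit leaves unreadable from compound 2 to compound 3), and a further limit is the likeliest report. Compound 3 is estimated at 0.6 h in this assay (expected range 0.3 h to 1.2 h).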

Compound 3, half-life: > 0.5 h
Compound 3 was reported as a limit; the forecaster's own chance of this, stated with the estimate: 65%; the middle value lies beyond the limit too.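

In this assay compound 3 gives > 0.5 h, a limit of the assay and not a number. Within the data shown here, compound 2 also stands at a limit, so no step from compound 2 to compound 3 can be read. The compounds shown leave open the actual half-life of each compound, and so any ranking among them, because all the data sit at one limit: the limit of > 0.5 h in this assay, at which 3 of the 3 values shown sit.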